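Expected half-life of compound 4 after its ring exchange

A few compounds are considered here, and "the series" means these few. Any claim that something is new, unique, unknown or untested is made for them only; others in the source may bear on it.

Compound 1 `CC(C)[C@H](C[C@H]1OC(=O)NC1=O)c1ccc(-c2ccc3cccc(F)c3c2)[nH]c1=O` gives 1.68 h in an ADME assay on microsomes from liver (Homo sapiens) for metabolic stability; on this read-out lower numbers stand for a shorter-lived compound and higher numbers for a longer-lived compound.
Compound 2 `C/C(=C1/OC(=O)NC1=O)C(c1ccc(-c2ccc3cccc(F)c3c2)[nH]c1=O)C(C)C` gives > 3 h in this assay, a limit of the measurement rather than a number.
Compound 3 `Cc1cc(C(/C=C2\OC(=O)NC2=O)C(C)C)c(=O)[nH]c1-c1ccc2cccc(F)c2c1` gives > 3 h in this assay, likewise a limit rather than a number.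

Compound 2 stands at the upper limit of this assay, and its reading is shared with compound 3, so that two of the three values sit at that limit (the limit of > 3 h in this assay, at which 2 of the 3 values shown sit); only compound 1 gives a finite number. Compound 4 `CC(C)C(/C=C1\NC(=O)NC1=O)c1ccc(-c2ccc3cccc(F)c3c2)[nH]c1=O` has not been measured. It differs from compound 2 by a group of 8 heavy atoms (4 carbon, 2 nitrogen, 2 oxygen; one five-membered non-aromatic ring with 2 hetero atoms) in place of a group of 9 heavy atoms (5 carbon, 1 nitrogen, 3 oxygen; one five-membered non-aromatic ring with 2 hetero atoms), on a saturated chain carbon bound to an aromatic carbon and a saturated chain carbon. Among the compounds with values here, no measured pair in the set differs in only one place, so nothing in the data shows how such a change moves the half-life. On what is shown, a step from compound 2 to compound 4 of no size beyond the usual scatter is expected, in neither direction, with a number no higher from compound 2 to compound 4 (the limit leaves the size open) as the expected change. For compound 4 the expected half-life in this assay is 3 h, within a range from 1.5 h to 6 h, with a fair chance that the assay again reports only a limit.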

Compound 4, half-life: > 3 h
Compound 4 was reported as a limit (the forecaster's own chance of this, stated with the estimate: 50%); the middle value lies on the limit itself.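

Compound 2 and compound 4 both stand at a limit of the measurement in this assay, so no step between them can be read: the limit of > 3 h in this assay, at which 3 of the 4 values shown sit.

The compounds shown leave open how long the half-lives of compound 2 and compound 4 really are, and whether exchanging one five-membered ring for the other changes the half-life at all.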